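The compounds below may be only part of what the source reports. "The series", "measured", "known", "first", "only" and "open" are said of these compounds alone.

Measured in an in vitro ADME assay on microsomes from liver (Homo sapiens) for metabolic stability, tested at 1 uM; on this read-out higher numbers stand for a longer-lived compound and lower numbers for a shorter-lived compound:
- compound 1 `CC(C)[C@]1(C(=O)N2C[C@@H]3C[C@H]2CN3C(=O)C(C)(C)C)CC[C@@H](NC2CCOCC2)C1` gives > 2 h (a limit)
- compound 2 `CC(C)[C@]1(C(=O)N2C[C@@H]3C[C@H]2CN3C(=O)C2CC2)CC[C@@H](NC2CCOCC2)C1` gives > 2 h (a limit)
- compound 3 `CC(C)[C@]1(C(=O)N2C[C@@H]3C[C@H]2CN3C(=O)C2CCOCC2)CC[C@@H](NC2CCOCC2)C1` gives > 2 h (a limit)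

Compound 1 is known only through a limit, not a number: the limit of > 2 h in this assay, at which 3 of the 3 values shown sit.

Compound 4 `CO[C@@H]1COCC[C@@H]1N[C@@H]1CC[C@@](C(=O)N2C[C@@H]3C[C@H]2CN3C(=O)C(C)(C)C)(C(C)C)C1` keeps the rest of compound 1 and carries one change: methoxy in place of hydrogen on a saturated ring carbon, oxan-4-yl to 3-methoxyoxan-4-yl.

The nearest measured changes are a step that the two limits leave unreadable from compound 1 to compound 2 and a step that the two limits leave unreadable from compound 1 to compound 3. Both fall on a carbonyl carbon, not at this place, and neither gives a size to carry over.

In this assay no step beyond the scatter is therefore expected, in neither direction. The expected change is a step that the limit leaves unreadable from compound 1 to compound 4 and it remains an estimate.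

Compound 4 is estimated at 2.5 h with an expected range of 1.2 h to 5 h. Compound 4 may well end up known only through a limit too.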

Compound 4, half-life: > 2 h
Compound 4 was reported as a limit (the forecaster's own chance of this, stated with the estimate: 70%); the middle value lies beyond the limit too.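

No step can be read from compound 1 to compound 4, as both are reported only as limits: the limit of > 2 h in this assay, at which 4 of the 4 values shown sit.

The compounds shown leave open the actual half-life of each, and so whether oxan-4-yl to 3-methoxyoxan-4-yl shifts it in either direction.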